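Methoxy for Bromo on the Aryl Ring of Compound 1

The compounds below may be only part of what the source reports. "The series", "measured", "known", "first", "only" and "open" are said of these compounds alone.

Measured compounds:
compound 1, `O=C(CSc1ncccn1)N/N=c1/scc(-c2ccc(Br)cc2)n1-c1ccccc1`, 72.1%
compound 2, `O=C(CSc1nnnn1-c1ccccc1)N/N=c1/scc(-c2ccccc2)n1-c1ccccc1`, 47.1%
compound 3, `Cc1nnc(SCC(=O)N/N=c2/scc(-c3ccc(F)cc3)n2-c2ccccc2)s1`, 73.7%

All three were tested in a functional assay on C6 cells (Rattus norvegicus) for cytotoxicity, read by MTT assay, with a stated time of 24 h, tested at 12 ug/mL; on this read-out lower numbers stand for a stronger effect and higher numbers for a weaker effect at the one concentration tested. In this assay compound 1 gives 72.1%, the second highest of the three numbers. Its nearest neighbour is compound 3, whose number is higher by only a small margin and lies within the scatter; compound 2 gives 47.1%, a lower number and a gap beyond the scatter. Compound 1 and compound 3 therefore cannot be told apart on these numbers, while compound 2 stands clearly apart from compound 1.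

Compound 4, `COc1ccc(-c2cs/c(=N/NC(=O)CSc3ncccn3)n2-c2ccccc2)cc1`, has not yet been measured. It differs from compound 1 in one place: methoxy in place of bromo on an aromatic carbon. The change sits on an aromatic carbon of a six-membered aromatic ring of carbon only, para to a large group.

Among the compounds with values here, no measured pair shows this change, so the account rests on compound 1 alone. The step of a number 2.1 percentage points lower from compound 1 to compound 4 (within the scatter) is expected to be small, none beyond the scatter, in no clear direction. Compound 4 is expected to give about 70%, within a range from 55% to 85%.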

Compound 4, a percentage reported as activity, at one concentration (the size of the read-out at that concentration, not a potency): 78.4%
Compound 4: the middle estimate sits 8.4 percentage points below what was measured; the range from low to high includes it.
By their numbers in this assay, from the lowest: compound 2; then compounds 1, 3 and 4 (each within the scatter of the next).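

Within the data shown here, the pair of compound 1 and compound 4 is the first in this set to differ in one place, so the change on this aromatic carbon can now be read directly. In this assay, replacing 4-bromophenyl with 4-methoxyphenyl gives a number 6.3 percentage points higher from compound 1 to compound 4 (within the scatter), so this single pair does not tell the two groups apart, even though methoxy brings a hydrogen-bond acceptor that bromo lacks. No measurement bears on why the two compounds read alike.

From the compounds shown here alone, it remains open whether any group at this position can move the number beyond the scatter, for instance an amine or a carboxylic acid. The compounds shown also leave open whether the same exchange would read alike on a compound that differs from compound 1 elsewhere in the structure.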